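Working notes on compound 3, a bromophenyl analogue

The compounds below may be only part of what the source reports. "The series", "measured", "known", "first", "only" and "open" are said of these compounds alone.

Measured so far:
compound 1 `COc1cc(OC)c(C(=O)/C=C/c2ccccc2SC)c(OC)c1` — 35%
compound 2 `COc1cc(OC)c(C(=O)/C=C/c2ccc(Cl)cc2)c(OC)c1` — 40%

In a functional assay on NCI-H727 cells (Homo sapiens), read by fluorescence and BrdU incorporation, with a stated time of 48 h, tested at 10 uM (a lower number here means a stronger effect, a higher number a weaker effect of the compound at the concentration tested), compound 1 gives 35%, the smaller of the two numbers shown, though the gap to compound 2 is within the scatter: a number 5 percentage points higher from compound 1 to compound 2 (within the scatter). Compound 3 `COc1cc(OC)c(C(=O)/C=C/c2ccc(Br)cc2)c(OC)c1` is not yet measured. It differs from compound 1 by 4-bromophenyl in place of 2-(methylsulfanyl)phenyl on a double-bonded chain carbon bound to a double-bonded chain carbon. Among the measured compounds shown here, the only step that bears on this change is the one to compound 2, which also replaces the 2-(methylsulfanyl)phenyl and stays within the scatter, so no step beyond the scatter is expected. Compound 3 is expected to give 40%, between 25% and 55%. That means an expected step of a number 5 percentage points higher from compound 1 to compound 3 (within the scatter).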

Compound 3, a percentage reported as activity, at one concentration (the size of the read-out at that concentration, not a potency): 39%
Compound 3: the middle estimate sits 1 percentage points above what was measured; the range from low to high includes it.
By their numbers in this assay, from the lowest: compounds 1, 3 and 2 (each within the scatter of the next).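

In this assay, bromo in place of chloro on an aromatic carbon gives a number 1 percentage points lower from compound 2 to compound 3 (within the scatter), so these two halogens are not told apart at this place. 4-Bromophenyl in place of 2-(methylsulfanyl)phenyl gives a number 4 percentage points higher from compound 1 to compound 3 (within the scatter), so a second replacement of that group on the double-bonded chain carbon also yields no step beyond the scatter. No supporting evidence bears on this result. On these data alone, whether an amine or a carboxylic acid in place of the halogen would give a step beyond the scatter remains open.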